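The source may report more compounds than this note shows. Statements on the series, on what has been measured and on what is new or still open speak of the compounds shown alone.

Measured so far in a functional assay on HCT-15 cells (Homo sapiens) for antiproliferative activity, read by sulforhodamine B assay; a lower number here means a stronger inhibitor of growth, a higher number a weaker inhibitor of growth:
- compound 1 `CC(C)=CCOc1cccc(O)c1C(=O)/C=C/c1ccc(O)cc1`: > 30000 nM (a limit of the assay, not a number)
- compound 2 `CC(C)CCOc1cccc(O)c1C(=O)/C=C/c1ccc(O)cc1`: 10600 nM
- compound 3 `CCC(CC)COc1cccc(O)c1C(=O)/C=C/c1ccc(O)cc1`: 3420 nM

Compound 3 has the lower of the two true numbers, and compound 2 is its nearest neighbour. The next structure is compound 4 `O=C(/C=C/c1ccc(O)cc1)c1c(O)cccc1OCCC1CCCC1`, with cyclopentylmethyl in place of pentan-3-yl on a saturated chain carbon bound to an oxygen on an aromatic ring (2-ethylbutoxy to 2-cyclopentylethoxy, cut one bond further out).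

Three measured steps change the same place. Within the data shown here, the only one between two true numbers is a 3.1-fold lower number from compound 2 to compound 3 (0.49 log units; beyond the scatter) and it is modest. The other two start from the limit: an at least 2.8-fold lower number from compound 1 to compound 2 (0.45 log units; beyond the scatter) and an at least 8.7-fold lower number from compound 1 to compound 3 (0.94 log units; beyond the scatter). None of these steps brings in a ring, so they bear on compound 4 only loosely. The number falls along these three compounds, and none goes against this, but three compounds are few.

The expected step is a 1.1-fold lower number from compound 3 to compound 4 (0.06 log units; within the scatter), and no change beyond the scatter is expected. For compound 4 the estimated value is 3000 nM, with an expected range from 1100 nM to 9000 nM.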

Compound 4, concentration for 50% growth inhibition: 3310 nM
Compound 4: middle estimate off by 1.1-fold (0.04 log units), on the low side, and the stated range covers the measured number.
By their numbers in this assay, from the lowest: compounds 4 and 3 (each within the scatter of the next); then compound 2. At a limit, above all of these: compound 1.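

In this assay, among these compounds, a five-membered carbon ring enters this place for the first time, and the open pentan-3-yl gives way to cyclopentylmethyl with a 1.0-fold lower number from compound 3 to compound 4 (0.01 log units; within the scatter), so the ring is tolerated on the saturated chain carbon bound to the oxygen on the aromatic ring. The ring-bearing chain also keeps the lower number seen with compound 3: a 3.2-fold lower number from compound 2 to compound 4 (0.51 log units; beyond the scatter), and an at least 9.0-fold lower number from compound 1 to compound 4 (0.95 log units; beyond the scatter). Compound 1 stands at a limit of the assay, not a number: the limit of > 30000 nM in this assay, at which 1 of the 4 values shown sits.

As far as these compounds go, whether a cyclohexyl ring, a phenyl ring or a longer chain at this place would move the number beyond the level of compound 3 and compound 4 remains open. Also open, from the compounds shown here alone, is whether an amine or a carboxylic acid on the chain would be accepted.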